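The source may hold more compounds than are shown below. What is called first, only, known or untested is meant among the compounds shown, and "the series" means these compounds.

Measured so far:
compound 1 `O=C(O)C12CCC(C(=O)N3CC[C@](c4ccc(C(F)(C(F)(F)F)C(F)(F)F)cc4)(S(=O)(=O)c4ccc(F)cc4)C3)(CC1)OC2` — 90%
compound 2 `O=C([C@H]1CC[C@H](c2nnn[nH]2)CC1)N1CC[C@](c2ccc(C(F)(C(F)(F)F)C(F)(F)F)cc2)(S(=O)(=O)c2ccc(F)cc2)C1` — 100%

In an ADME assay on microsomes from liver (Homo sapiens) for metabolic stability, with a stated time of 10 min (on this read-out higher numbers stand for a more stable compound and lower numbers for a less stable compound), compound 2 gives 100%, the higher of the two numbers, and compound 1 gives 90%. Among the compounds with values here, the one measured step, a number 10 percentage points higher from compound 1 to compound 2 (within the scatter), lies within the scatter, so the two compounds cannot be told apart on this read-out.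

Compound 3 `O=C(N1CC[C@](c2ccc(C(F)(C(F)(F)F)C(F)(F)F)cc2)(S(=O)(=O)c2ccc(F)cc2)C1)C1(F)CCS(=O)(=O)CC1` differs from compound 2 in one place: 4-fluoro-1,1-dioxothian-4-yl in place of 4-(1H-tetrazol-5-yl)cyclohexyl on a carbonyl carbon. Within the data shown here, the only step that bears on this change is the one from compound 1 to compound 2, which also exchanged the whole group on that carbonyl carbon, and it stayed within the scatter. On that basis no step beyond the scatter is expected for compound 3 in this assay, with a number 10 percentage points lower from compound 2 to compound 3 (within the scatter) as the expected change. Compound 3 is therefore estimated at 90%, within a range from 70% to 100%.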

Compound 3, percent of the compound remaining: 100%
For compound 3 the middle estimate is 10 percentage points below the measured one, within the range that was stated.
By their numbers in this assay, from the lowest: compounds 1, 2 and 3 (each within the scatter of the next).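

Replacing 4-(1H-tetrazol-5-yl)cyclohexyl with 4-fluoro-1,1-dioxothian-4-yl on the carbonyl carbon gives, in this assay, no change at the digits printed from compound 2 to compound 3 (within the scatter), so this position also accepts a smaller group with a sulfur atom, a fluorine atom and no hydrogen-bond donor. Set against the group in compound 1, the same new group gives a number 10 percentage points higher from compound 1 to compound 3 (within the scatter), which leaves all three groups on this carbonyl carbon within the scatter of one another. Nothing measured here explains why the read-out stays so level across these different groups.

The compounds shown leave open whether this stability would hold with an amine or a longer open alkyl chain on the same carbonyl carbon. They also leave open whether any group at this position can lower the read-out beyond the scatter.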